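This account rests on a few compounds, and the source may have more. Where it says the series, first, only, none or still open, it means among the compounds named here.

Measured so far:
Compound 1 `CCCCNc1nc(N)nc(C)c1C#CCN1CCCCC1`: 3790 nM
Compound 2 `CCCCNc1nc(N)nc(C)c1CCc1ccccc1`: 1190 nM

In an assay on HEK293 cells for agonist activity at Toll-like receptor 8 (Homo sapiens), read by spectrophotometry (on this read-out lower numbers stand for an effect already at smaller amounts and higher numbers for an effect only at larger amounts of compound), compound 2 gives the lowest of the two numbers, while compound 1 sits higher, a gap beyond the usual scatter. Compound 3 `CCCCNc1nc(N)nc(C)c1CCCn1cccn1` differs from compound 2 in one place: (1H-pyrazol-1-yl)methyl in place of phenyl on a saturated chain carbon, two bonds along the chain from an aromatic carbon. Among the measured compounds shown here, no measured pair shares this change, so there is no step to lean on. The expected step is a 1.8-fold higher number from compound 2 to compound 3 (0.27 log units; within the scatter), a modest shift toward higher numbers, with little confidence in its size. Compound 3 is therefore estimated at 2200 nM, within 700 nM to 7000 nM.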

Compound 3, half-maximal effective concentration: 1050 nM
For compound 3 the middle estimate is 2.1-fold (0.32 log units) above the measured one; measured number inside the range.
By their numbers in this assay, from the lowest: compounds 3 and 2 (each within the scatter of the next); then compound 1.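

In this assay, putting (1H-pyrazol-1-yl)methyl in place of phenyl on this saturated chain gives a 1.1-fold lower number from compound 2 to compound 3 (0.05 log units; within the scatter), so the two compounds cannot be told apart. This place on the chain therefore accepts a five-membered aromatic ring with 2 hetero atoms as readily as a six-membered ring of carbon only, at least for this pair. Nothing available explains why the two numbers match. From the compounds shown here alone, whether a carboxylic acid or an amine at this place, or a longer chain, would keep the number in this range remains open.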